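The source may hold more compounds than are shown below. What is called first, only, known or untested is meant among the compounds shown, and "the series" means these compounds.

Measured compounds:
- compound 1 `CCS(=O)(=O)c1ccc(COC[C@@H]2C[C@@H]2C2CCN(c3nc(C(C)C)no3)CC2)c(F)c1`: 0.8 nM
- compound 2 `COCc1cnc(N2CCC([C@H]3C[C@H]3COCc3ccc(S(C)(=O)=O)c(F)c3)CC2)nc1`: 3.3 nM

Both were tested in a functional assay on CHO cells for agonist activity at Glucose-dependent insulinotropic receptor (Homo sapiens), read by cAMP accumulation; a lower number here means that less compound is needed, a higher number that more compound is needed for the effect. Of the two numbers, compound 2 has the highest; the nearest is compound 1, whose number is lower by a gap that lies beyond the usual scatter of this assay.

Compound 3 `CCc1cnc(N2CCC([C@H]3C[C@H]3COCc3ccc(S(C)(=O)=O)c(F)c3)CC2)nc1` is not yet measured. It differs from compound 2 in one place: methyl in place of methoxy on a saturated chain carbon bound to an aromatic carbon. For the measured compounds named here, no measured pair in this set shows the effect of that change, so the expectation rests on compound 2 alone. The change is small in size, and a step of modest extent is expected, if any beyond the scatter, more likely towards a somewhat higher number than a lower one. The step is expected to be a 1.5-fold higher number from compound 2 to compound 3 (0.18 log units; within the scatter). In this assay compound 3 is therefore estimated at 5 nM, with a plausible range from 1.5 nM to 15 nM.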

Compound 3, half-maximal effective concentration in the Glucose-dependent insulinotropic receptor assay: 2.5 nM
For compound 3 the middle estimate is 2.0-fold (0.30 log units) above the measured one, and the stated range covers the measured number.
By their numbers in the Glucose-dependent insulinotropic receptor assay, from the lowest: compound 1; then compounds 3 and 2 (each within the scatter of the next).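

In the Glucose-dependent insulinotropic receptor assay, replacing methoxy with methyl on a saturated chain carbon bound to an aromatic carbon gives a 1.3-fold lower number from compound 2 to compound 3 (0.12 log units; within the scatter). At this position, then, the oxygen and the hydrogen-bond acceptor that leaves with it can be removed without a shift that this assay can separate from its usual scatter. In a physicochemical assay for lipophilicity, read by HPLC, at pH 7 (a lower number here means a more polar compound, a higher number a more lipophilic compound), compound 2 gives 3.5 and compound 3 gives 4.3. The same swap does register in the physicochemical assay, so this position can carry a clear change in lipophilicity while the receptor response holds steady: the measured distribution coefficient of compound 2, 3.5, and of compound 3, 4.3, a number 0.80 log units higher (beyond the scatter)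

As far as these compounds go, whether this tolerance extends further remains open, since a longer chain, a hydroxyl or an amine in this place could give quite a different result. Compound 1 differs from both compounds in more than one place, so it adds nothing on this question.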